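Swapping the aromatic group on compound 2

This account rests on a few compounds, and the source may have more. Where it says the series, first, only, none or still open, it means among the compounds named here.

compound 1 `CCCCOC(=O)CC1c2cccc(C)c2S(=O)(=O)N1C(=O)c1ccco1` — "not determined" (no result reported)
compound 2 `CCCCOC(=O)CC1c2cccc(C)c2S(=O)(=O)N1C(=O)c1ccc(C#N)cc1` — 3830 nM

Within the data shown here, compound 2 is the only compound with a number here; in an assay on HEK-Blue hNOD1 cells for antagonist activity at Nucleotide-binding oligomerization domain-containing protein 1 (Homo sapiens), read by reporter gene assay, with stated times of 3 h and 20 h (on this read-out lower numbers stand for stronger inhibition and higher numbers for weaker inhibition), compound 2 gives 3830 nM, while for compound 1 the outcome was "not determined" (no result reported). Compound 3 `CCCCOC(=O)CC1c2cccc(C)c2S(=O)(=O)N1C(=O)c1cccc(C(F)(F)F)c1` differs from compound 2 by one change: 3-(trifluoromethyl)phenyl in place of 4-cyanophenyl on a carbonyl carbon. Among the measured compounds shown here, no measured pair shows what such a change does, so the step of a 1.2-fold higher number from compound 2 to compound 3 (0.07 log units; within the scatter) is expected to stay within the usual scatter, with no clear direction. Compound 3 is therefore estimated at 4500 nM, with a likely range from 1500 nM to 14000 nM.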

Compound 3, half-maximal inhibitory concentration: 1050 nM
The estimate for compound 3 lay 4.3-fold (0.63 log units) above the measured number; the measured number lies below the stated range.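

Replacing 4-cyanophenyl with 3-(trifluoromethyl)phenyl on the carbonyl carbon gives a 3.6-fold lower number from compound 2 to compound 3 (0.56 log units; beyond the scatter) in this assay. This first readable comparison shows that the aromatic group at this position can change the measured inhibition by more than the usual scatter. The data give no explanation for this drop.

Compound 1 has no number, so it offers no comparison at this position. On these data alone, it remains open whether a plain phenyl, a 3-chlorophenyl or a 3-aminophenyl group would give a lower or higher number than compound 3.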